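The source may hold more compounds than are shown below. What is called first, only, known or untested is meant among the compounds shown, and "the series" means these compounds.

Compound 1 `COc1ccc(C(F)(F)F)cc1Nc1ncc(C(F)(F)F)c(N2Cc3cccc(N(C)S(C)(=O)=O)c3C2)n1` carries a 2-methoxy-5-(trifluoromethyl)phenyl group on the anilino nitrogen of the shared core. In a functional assay on A549 cells (Homo sapiens) for antiproliferative activity, read by spectrophotometry, with a stated time of 2 days (on this read-out lower numbers stand for stronger inhibition of growth and higher numbers for weaker inhibition of growth), compound 1 gives only a limit of > 30000 nM, so no number stands for it. This places compound 1 at the limit of > 30000 nM in this assay, at which 1 of the 2 values shown sits, the weak end of everything measured here. Compound 2 `COc1cc(N2CCN(C(C)=O)CC2)ccc1Nc1ncc(C(F)(F)F)c(N2Cc3cccc(N(C)S(C)(=O)=O)c3C2)n1` keeps the same core and, in this assay, gives 3300 nM, a number rather than a limit. Compound 3 `COc1cc(Nc2ncc(C(F)(F)F)c(N3Cc4cccc(N(C)S(C)(=O)=O)c4C3)n2)cc(C(F)(F)F)c1` has not been measured in this assay. It differs from compound 1 in one place: 3-methoxy-5-(trifluoromethyl)phenyl in place of 2-methoxy-5-(trifluoromethyl)phenyl on a nitrogen on an aromatic ring. Going by the values given here, no step between two measured compounds shows what such a rearrangement of the same atoms does. With compound 1 at a limit, the most one can say is that compound 3 is expected to stay near that limit, so the step from compound 1 to compound 3 is expected to be an at least 1.5-fold lower number from compound 1 to compound 3 (0.17 log units; that floor lies within the scatter), with a fair chance that this assay again returns only a limit. Compound 3 is therefore estimated at 20000 nM, with a plausible range from 5000 nM to 60000 nM.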

Compound 3, concentration for 50% growth inhibition: > 30000 nM
Compound 3 was reported as a limit; the forecaster's own chance of this, stated with the estimate: 50%; middle value at least 1.5-fold (0.17 log units) from the limit.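

In this assay compound 3 gives > 30000 nM, which is a limit and not a number. Going by these compounds alone, compound 1 also stands at a limit, so no step from compound 1 to compound 3 can be read: the limit of > 30000 nM in this assay, at which 2 of the 3 values shown sit. The compounds shown leave open whether 3-methoxy-5-(trifluoromethyl)phenyl and 2-methoxy-5-(trifluoromethyl)phenyl differ at all in this assay.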